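The source may hold more compounds than are shown below. What is called first, only, known or untested is meant among the compounds shown, and "the series" means these compounds.

Working notes on the series.

Compound 1 `COc1cc2nc(N3CCN(C(=O)c4ccc(C(C)(C)C)cc4)CC3)nc(N)c2cc1OC` carries the shared core joined through an amide to a tert-butyl-substituted phenyl ring. In a functional assay on PC-3 cells (Homo sapiens) for inhibition (a lower number here means a stronger inhibitor, a higher number a weaker inhibitor), compound 1 gives 47000 nM. Compound 2 `COc1cc2nc(N3CCN(S(=O)(=O)c4cccc([N+](=O)[O-])c4)CC3)nc(N)c2cc1OC` keeps the same core but joins it through a sulfonyl group to a 3-nitrophenyl ring. In this assay compound 2 gives 32000 nM. The two numbers lie within the scatter of each other, so no order between compound 1 and compound 2 can be read from them; both sit in the weak range.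

Compound 3 `COc1cc2nc(N3CCN(S(=O)(=O)c4cccc(C(=O)O)c4)CC3)nc(N)c2cc1OC` differs from compound 2 in one place: carboxy in place of nitro on an aromatic carbon. Among the compounds with values here, no measured pair shows this kind of exchange, so there is no step to lean on. Given that compound 2 gives 32000 nM and the surrounding values all sit high, the step from the change is expected to be small, a 1.3-fold higher number from compound 2 to compound 3 (0.10 log units; within the scatter), and not beyond the scatter in either direction. Compound 3 is therefore estimated at 40000 nM, with a range from 15000 nM to 110000 nM.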

Compound 3, half-maximal inhibitory concentration: 53000 nM
The estimate for compound 3 lay 1.3-fold (0.12 log units) below the measured number; the range from low to high includes it.
By their numbers in this assay, from the lowest: compounds 2, 1 and 3 (each within the scatter of the next).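

Within the data shown here, the exchange of nitro for carboxy, on an aromatic carbon meta to a large group, gives the first step that can be read: in this assay it is a 1.7-fold higher number from compound 2 to compound 3 (0.22 log units; within the scatter). At this place, 3-nitrophenyl and 3-carboxyphenyl therefore cannot be told apart, although carboxy brings 1 hydrogen-bond donor where nitro has 0, and compound 2 and compound 3 both stay in the weak range. No supporting data bear on why the exchange gives this result.

Going by these compounds, whether an amine or a methyl ester at this same place would give a number beyond the scatter from compound 2 remains open, as does whether any group here can lift the series out of the weak range. Compound 1 differs from compound 2 in more than one place, so the shown compounds also leave open how the amide link and the sulfonyl link compare when they carry the same aromatic ring.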